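The source may report more compounds than this note shows. Statements on the series, on what has been measured and on what is new or still open speak of the compounds shown alone.

Measured compounds in a functional assay on SMMC-7721 cells (Homo sapiens) for cytotoxicity, read by MTT assay, with a stated time of 4 days; on this read-out lower numbers stand for stronger inhibition and higher numbers for weaker inhibition:

Compound 1 `COc1ccc(-c2cn(C[C@H]3c4c(ccc(O)c4C)[C@@H]4CC[C@@]5(C)C[C@]43CC5=O)nn2)cc1` gives > 20000 nM, which is a limit of the assay and not a number.
Compound 2 `Cc1c(O)ccc2c1[C@H](Cn1cc(-c3ccc(F)cc3)nn1)[C@@]13CC(=O)[C@@](C)(CC[C@@H]21)C3` gives > 20000 nM, again only a limit of the assay.
Compound 3 `Cc1c(O)ccc2c1[C@H](Cn1cc(-c3ccc(Cl)cc3)nn1)[C@@]13CC(=O)[C@@](C)(CC[C@@H]21)C3` gives > 20000 nM, likewise a limit of the assay.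

Compound 3 therefore stands nowhere on a scale of numbers: in this assay it sits at the limit of > 20000 nM in this assay, at which 3 of the 3 values shown sit, together with the two other values shown. The three steps that join the measured compounds, a step that the two limits leave unreadable from compound 1 to compound 2, a step that the two limits leave unreadable from compound 1 to compound 3 and a step that the two limits leave unreadable from compound 2 to compound 3, are each a change of one aromatic substituent whose size cannot be read, since both ends of each step are limits.

Compound 4 `Cc1c(O)ccc2c1[C@H](Cn1cc(-c3ccccn3)nn1)[C@@]13CC(=O)[C@@](C)(CC[C@@H]21)C3` differs from compound 3 by pyridin-2-yl in place of 4-chlorophenyl on an aromatic carbon. All three measured steps concern the same aromatic carbon on the five-membered ring and all are unreadable, so none of them gives a size for a move from compound 3 to compound 4, and no step beyond the scatter can be read into the data for this assay.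

The expectation is that compound 4 remains at or near the limit in this assay, estimated at 25000 nM with a range of 8000 nM to 80000 nM. The step that the limit leaves unreadable from compound 3 to compound 4 is the estimated consequence, with a high chance that only a limit is reported.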

Compound 4, half-maximal inhibitory concentration: > 20000 nM
Compound 4: only a limit was reported; the forecaster's own chance of this, stated with the estimate: 80%; the middle value lies beyond the limit too.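

No new step can be read among compound 1, compound 2, compound 3 and compound 4, as each result is a limit and not a number: the limit of > 20000 nM in this assay, at which 4 of the 4 values shown sit. The compounds shown leave open whether any aromatic group at this place on the shared core would give a measurable value in this assay.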